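Swapping the benzylic aryl group and rat oral exposure

The source may hold more compounds than are shown below. What is called first, only, known or untested is meant among the compounds shown, and "the series" means these compounds.

Compound 3 `COc1ccccc1CNC1(CCC(C)(C)C)C(=O)C(C2=NS(=O)(=O)c3cc(NS(C)(=O)=O)ccc3N2)=C(O)c2ccccc21` gives 48% in an in vivo ADME assay on the whole organism (strain Sprague-Dawley) for pharmacokinetics, with Rattus norvegicus as the target, at a dose of 5 mg/kg by the oral route (a lower number here means that a smaller share of the oral dose reaches the circulation, a higher number that a larger share of the oral dose reaches the circulation), the highest of the three numbers measured. Compound 2 `CC(C)(C)CCC1(NCc2ccc3ccccc3c2)C(=O)C(C2=NS(=O)(=O)c3cc(NS(C)(=O)=O)ccc3N2)=C(O)c2ccccc21` gives 28.1% in this assay, and compound 1 `Cc1ccc(CNC2(CCC(C)(C)C)C(=O)C(C3=NS(=O)(=O)c4cc(NS(C)(=O)=O)ccc4N3)=C(O)c3ccccc32)cn1` gives 0%. The steps of a number 28.1 percentage points higher from compound 1 to compound 2 (beyond the scatter) and a number 48 percentage points higher from compound 1 to compound 3 (beyond the scatter) show that exchanging the group on the saturated chain carbon bound to the amine nitrogen moves the read-out well beyond the scatter. Compound 4 `Cc1cccc(C)c1CNC1(CCC(C)(C)C)C(=O)C(C2=NS(=O)(=O)c3cc(NS(C)(=O)=O)ccc3N2)=C(O)c2ccccc21` differs from compound 3 by 2,6-dimethylphenyl in place of 2-methoxyphenyl on a saturated chain carbon bound to an amine nitrogen. Among the compounds with values here, no measured step involves 2,6-dimethylphenyl; the nearest guide is the aryl-for-aryl exchange a number 19.9 percentage points higher from compound 2 to compound 3 (beyond the scatter), a modest shift. Compound 4 is therefore expected to give 35% in this assay, within 15% to 55%. The estimated step is a number 13 percentage points lower from compound 3 to compound 4 (beyond the scatter), a modest fall.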

Compound 4, oral bioavailability: 53.7%
Compound 4: middle estimate off by 18.7 percentage points, on the low side, and the stated range covers the measured number.
By their numbers in this assay, from the lowest: compound 1; then compound 2; then compounds 3 and 4 (each within the scatter of the next).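

Putting 2,6-dimethylphenyl in place of 2-methoxyphenyl gives a number 5.7 percentage points higher from compound 3 to compound 4 (within the scatter) in this assay, so replacing this oxygen-bearing aryl group with one containing only carbon leaves oral bioavailability within the scatter. The steps of a number 25.6 percentage points higher from compound 2 to compound 4 (beyond the scatter) and a number 53.7 percentage points higher from compound 1 to compound 4 (beyond the scatter) place this new group, like 2-methoxyphenyl, clear of naphthalen-2-yl and 6-methylpyridin-3-yl. Nothing available here accounts for these differences.

Still open, from the compounds shown here alone, is how unsubstituted phenyl, cyclohexyl or a carboxylic acid would fare on this saturated chain carbon bound to an amine nitrogen in this assay and whether either methyl group of 2,6-dimethylphenyl could be removed without leaving this level.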